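Replacing Trifluoromethyl with Nitro on a Shared Core

A few compounds are considered here, and "the series" means these few. Any claim that something is new, unique, unknown or untested is made for them only; others in the source may bear on it.

Of the compounds shown here, two built on the same core have been measured so far. Compound 1 `CC1=CC[C@H](C(C)C)c2cc(C)c(OC(=O)c3ccc(Cl)cc3)cc21` and compound 2 `CC1=CC[C@H](C(C)C)c2cc(C)c(OC(=O)c3cccc(C(F)(F)F)c3)cc21` differ only in the group carried on the aromatic ring of the acyl portion. In a functional assay on MCF7 cells (Homo sapiens) for antiproliferative activity, read by sulforhodamine B assay, with a stated time of 48 h, tested at 50 uM (on this read-out higher numbers stand for more inhibition at the one concentration tested (going by the name of the read-out) and lower numbers for less inhibition), compound 1 gives 79.7%, and in this assay compound 2 gives 86%. Of the two numbers, that of compound 2 is the larger, but its gap to compound 1 lies within the scatter, so the two compounds are not told apart by this read-out. Compound 3 `CC1=CC[C@H](C(C)C)c2cc(C)c(OC(=O)c3cccc([N+](=O)[O-])c3)cc21` now joins them; it differs from compound 2 by nitro in place of trifluoromethyl on an aromatic carbon. For the measured compounds named here, no measured step between compounds differing in one place is available to guide an expectation. Since compound 2 gives 86% in this assay, the step of a number 6 percentage points lower from compound 2 to compound 3 (within the scatter) is expected to stay within the scatter, with no clear direction. Compound 3 is accordingly estimated to give 80% in this assay, within a range from 64% to 92%.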

Compound 3, a percentage reported as inhibition, at one concentration (the size of the read-out at that concentration, not a potency): 29.3%
Compound 3: middle estimate off by 50.7 percentage points, on the high side, outside the stated range (below it).
By their numbers in this assay, from the lowest: compound 3; then compounds 1 and 2 (each within the scatter of the next).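

In this assay the aromatic ring of the acyl portion proves sensitive to what it carries: nitro in place of trifluoromethyl on an aromatic carbon, meta to a large group, gives a number 56.7 percentage points lower from compound 2 to compound 3 (beyond the scatter) and thus a clear separation, which compound 1 and compound 2 had not provided. The change of 4-chlorophenyl to 3-nitrophenyl on the carbonyl carbon gives a number 50.4 percentage points lower from compound 1 to compound 3 (beyond the scatter) and so points the same way, although that step changes both the group and its place on the ring. Nothing available bears on the reason for this drop.

On these data alone, whether an amine, a nitrile or a methoxy group at this place would track trifluoromethyl or nitro remains open. Also open, as far as these compounds go, is whether nitro elsewhere on the ring would give a similarly low number.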